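Cyclohexyl in place of pentyloxy: what to expect of compound 4

The source may hold more compounds than are shown below. What is called first, only, known or untested is meant among the compounds shown, and "the series" means these compounds.

Values in a functional assay on brain (Rattus norvegicus, strain Wistar) for inhibition; on this read-out higher numbers stand for weaker inhibition and lower numbers for stronger inhibition:
- compound 1 `Cc1[nH]c(=O)n(C)c1-c1ccccc1`: > 100000 nM (a limit of the assay, not a number)
- compound 2 `CCCc1ccc(-c2c(C)[nH]c(=O)n2C)cc1`: 21500 nM
- compound 3 `CCCCCOc1ccc(-c2c(C)[nH]c(=O)n2C)cc1`: 4500 nM

Compound 3 has the lowest number of the three in this assay, and compound 2 is its nearest neighbour. The unmeasured compound 4 `Cc1[nH]c(=O)n(C)c1-c1ccc(C2CCCCC2)cc1` has cyclohexyl in place of pentyloxy on an aromatic carbon.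

Going by the values given here, three measured steps bear on this change. Two of them start from a limit: an at least 4.6-fold lower number from compound 1 to compound 2 (0.66 log units; beyond the scatter) and an at least 22-fold lower number from compound 1 to compound 3 (1.34 log units; beyond the scatter). Both show a lower number when a group replaces hydrogen. Among the compounds with values here, the closest precedent is a 4.8-fold lower number from compound 2 to compound 3 (0.68 log units; beyond the scatter), which exchanges one group for another and lies beyond the scatter. Within the data shown here, no measured step compares a ring with an open chain, so the direction of the change remains open. No step beyond the scatter is therefore expected, and the step is estimated as a 1.3-fold higher number from compound 3 to compound 4 (0.12 log units; within the scatter). For compound 4 the expected value in this assay is 6000 nM, with an estimated range from 2000 nM to 18000 nM.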

Compound 4, half-maximal inhibitory concentration: 10000 nM
Compound 4: the middle estimate sits 1.7-fold (0.22 log units) below what was measured, and the stated range covers the measured number.
By their numbers in this assay, from the lowest: compound 3; then compound 4; then compound 2. At a limit, above all of these: compound 1.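

In this assay, going by these compounds alone, compound 4 gives the first comparison of a ring with an open chain at this position, and the ring does not match the chain: a 2.2-fold higher number from compound 3 to compound 4 (0.35 log units; beyond the scatter). It still improves on the shorter chain, with a 2.2-fold lower number from compound 2 to compound 4 (0.33 log units; beyond the scatter), so both groups of 6 heavy atoms give lower numbers than propyl, yet the gap between them shows that heavy-atom count alone does not set the number. The remaining step, an at least 10-fold lower number from compound 1 to compound 4 (1.00 log units; beyond the scatter), gives only a bound, since compound 1 stands at a limit, not a number: the limit of > 100000 nM in this assay, at which 1 of the 4 values shown sits.

The compounds shown do not separate the oxygen of pentyloxy from the open shape of its chain, which a plain hexyl chain or a cyclopentyloxy group would address. From the compounds shown here alone, whether an amine or a carboxylic acid is tolerated on this carbon also remains open.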